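Aryl exchange at the cyano-flanked carbon of the core

This account rests on a few compounds, and the source may have more. Where it says the series, first, only, none or still open, it means among the compounds named here.

Three measured compounds share one core and differ only in the aryl group on one aromatic carbon. Compound 1 `CCOc1nc(-c2cc3ccccc3o2)cc(-c2cccc3ccccc23)c1C#N` gives in a functional assay on aorta (strain Wistar) for inhibition, with Thoracic aorta (Rattus norvegicus) as the target (on this read-out lower numbers stand for stronger inhibition and higher numbers for weaker inhibition), a value of 344000 nM. Compound 2 `CCOc1nc(-c2cc3ccccc3o2)cc(-c2ccc(Cl)cc2)c1C#N` gives 221000 nM in this assay. Compound 3 `CCOc1nc(-c2cc3ccccc3o2)cc(-c2ccc(OC)cc2OC)c1C#N` gives 488000 nM, the highest of the three numbers; the step of a 1.4-fold higher number from compound 1 to compound 3 (0.15 log units; within the scatter) lies within the scatter, whereas the step of a 2.2-fold higher number from compound 2 to compound 3 (0.34 log units; beyond the scatter) is modest but beyond it. Compound 4 `CCOc1nc(-c2cc3ccccc3o2)cc(-c2cccs2)c1C#N` has not been measured in this assay.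

The change from compound 3 to compound 4 is thiophen-2-yl in place of 2,4-dimethoxyphenyl on an aromatic carbon. Within the data shown here, two measured steps bear on it, both exchanges of the aryl group at the same carbon: a 1.4-fold higher number from compound 1 to compound 3 (0.15 log units; within the scatter) and a 2.2-fold higher number from compound 2 to compound 3 (0.34 log units; beyond the scatter). Among the measured compounds shown here, no measured compound carries a thiophen-2-yl group, so the direction for that group itself is unknown. The exchanges seen so far moved the number little; the only one beyond the scatter ran upward when the 2,4-dimethoxyphenyl entered. Removing it is therefore expected to give at most a modest step toward a lower number, possibly none beyond the scatter. For compound 4 the estimated value in this assay is 260000 nM, with a range from 110000 nM to 620000 nM. The expected step is a 1.9-fold lower number from compound 3 to compound 4 (0.27 log units; within the scatter).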

Compound 4, half-maximal inhibitory concentration: 308000 nM
Beside the measured number, compound 4's estimate is 1.2-fold (0.07 log units) below it; measured number inside the range.
By their numbers in this assay, from the lowest: compounds 2, 4, 1 and 3 (each within the scatter of the next, the first and the last beyond it).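

Thiophen-2-yl brings a five-membered aromatic ring with a sulfur atom to this carbon, opposite the ring nitrogen, and all three new steps stay within the scatter: against 2,4-dimethoxyphenyl (a 1.6-fold lower number from compound 3 to compound 4 (0.20 log units; within the scatter)), against 4-chlorophenyl (a 1.4-fold higher number from compound 2 to compound 4 (0.14 log units; within the scatter)) and against naphthalen-1-yl (a 1.1-fold lower number from compound 1 to compound 4 (0.05 log units; within the scatter)). In this assay, among these compounds, a group of 5 heavy atoms therefore cannot be told apart from one of 10 heavy atoms, and the earlier difference between the 4-chlorophenyl and 2,4-dimethoxyphenyl groups remains the only step beyond the scatter, with compound 4 within the scatter of both compounds. Nothing available here accounts for how little these aryl exchanges change the read-out.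

Going by these compounds, whether an amine, a carboxylic acid or a longer alkyl chain at this carbon would move the number beyond the scatter remains open, as all four groups compared are aromatic rings. On these data alone, the ethoxy, cyano and 1-benzofuran-2-yl groups are the same throughout, so the effect of exchanging any of them on the read-out also stays open.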